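This account rests on a few compounds, and the source may have more. Where it says the series, first, only, none or still open, it means among the compounds named here.

Measured in a functional assay on A549 cells (Homo sapiens) for antiproliferative activity, read by MTT assay; on this read-out higher numbers stand for weaker inhibition and lower numbers for stronger inhibition:
- compound 1 `COC(=O)N1CCCc2cc(S(=O)(=O)N3CC(c4ccccc4)NC3=O)ccc21`: 1150 nM
- compound 2 `CCCCOC(=O)N1CCCc2cc(S(=O)(=O)N3CC(c4ccccc4)NC3=O)ccc21`: > 20000 nM (a limit of the assay)
- compound 3 `NC(=O)N1CCCc2cc(S(=O)(=O)N3CC(c4ccccc4)NC3=O)ccc21`: 2540 nM

Compound 2 gives only a limit, > 20000 nM, and no number.

Compound 4 `O=C(NC1CCCCC1)N1CCCc2cc(S(=O)(=O)N3CC(c4ccccc4)NC3=O)ccc21` has not yet been measured in this assay. Its difference from compound 2 is cyclohexylamino in place of butoxy on a carbonyl carbon.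

For the measured compounds named here, three measured steps bear on this change. The closest is amino in place of butoxy on the same carbonyl carbon, which gave an at least 7.8-fold lower number from compound 2 to compound 3 (0.89 log units; beyond the scatter). Amino in place of methoxy gave a 2.2-fold higher number from compound 1 to compound 3 (0.34 log units; beyond the scatter), a far smaller change. Propyl added to the methoxy carbon gave an at least 17-fold higher number from compound 1 to compound 2 (1.24 log units; beyond the scatter), so the larger of the two alkoxy groups sits at the weak end of the series. Going by the values given here, no measured compound carries cyclohexylamino, and the group that enters is bigger than the plain amino of compound 3, so the size of the step remains uncertain.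

A modest step toward a lower number is therefore expected in this assay, with a real chance that the result stays at the limit. The expected change is an at least 3.3-fold lower number from compound 2 to compound 4 (0.52 log units; beyond the scatter). Compound 4 is estimated at 6000 nM, with an expected range of 1800 nM to 20000 nM.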

Compound 4, half-maximal inhibitory concentration: 231 nM
For compound 4 the middle estimate is 26-fold (1.41 log units) above the measured one, outside the stated range (below it).
By their numbers in this assay, from the lowest: compound 4; then compound 1; then compound 3. At a limit, above all of these: compound 2.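

In this assay, a large group on this carbonyl carbon is not in itself a penalty: in the alkoxy pair, lengthening methoxy to butoxy gave an at least 17-fold higher number from compound 1 to compound 2 (1.24 log units; beyond the scatter), whereas cyclohexyl in place of hydrogen on the amide-type nitrogen gave an 11-fold lower number from compound 3 to compound 4 (1.04 log units; beyond the scatter). Nitrogen in place of oxygen does not fix the direction either, since plain amino in place of methoxy gave a 2.2-fold higher number from compound 1 to compound 3 (0.34 log units; beyond the scatter), while cyclohexylamino in place of methoxy gave a 5.0-fold lower number from compound 1 to compound 4 (0.70 log units; beyond the scatter), leaving compound 4 with the lowest number of the series. Cyclohexylamino in place of butoxy gave an at least 86-fold lower number from compound 2 to compound 4 (1.93 log units; beyond the scatter), a step whose true size stays unknown, as compound 2 stands at a limit of the assay: the limit of > 20000 nM in this assay, at which 1 of the 4 values shown sits.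

The compounds shown leave open whether the gain depends on the ring itself, which a butylamino group on the same carbonyl carbon would test against an open chain of similar length. They also leave open whether the amide hydrogen matters, which a piperidine-1-carbonyl group in place of cyclohexylcarbamoyl would address.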